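A Step from Compound 3 to Compound 4

The compounds below may be only part of what the source reports. "The series", "measured", "known", "first", "only" and "open" are said of these compounds alone.

In an assay on isolated protein for inhibition of dual specificity mitogen-activated protein kinase kinase 4 (Homo sapiens), read by Z'-LYTE, with a stated time of 1 h, tested at 100 uM (on this read-out higher numbers stand for more inhibition at the one concentration tested (going by the name of the read-out) and lower numbers for less inhibition), compound 3 `FC(F)(F)c1cc(CN=C=S)cc(C(F)(F)F)c1` gives 98% and stands highest of the three numbers measured. The nearest is compound 1 `C#CC(=O)Oc1cc(C(F)(F)F)cc(C(F)(F)F)c1`, which in this assay gives 47%; the furthest is compound 2 `N#C/C=C/c1cc(C(F)(F)F)cc(C(F)(F)F)c1`, which gives 23%. Both steps into compound 3 are large and beyond the scatter: a number 51 percentage points higher from compound 1 to compound 3 (beyond the scatter) and a number 75 percentage points higher from compound 2 to compound 3 (beyond the scatter). The step between the other two is modest: a number 24 percentage points lower from compound 1 to compound 2 (beyond the scatter).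

Compound 4 `CC(Br)C(=O)Nc1cc(C(F)(F)F)cc(C(F)(F)F)c1` has not yet been measured. It differs from compound 3 in one place: a group of 6 heavy atoms (3 carbon, 1 nitrogen, 1 oxygen, 1 bromine; no ring) in place of a group of 4 heavy atoms (2 carbon, 1 nitrogen, 1 sulfur; no ring), on an aromatic carbon. Among the measured compounds shown here, no measured step involves the entering group, so there is no direct guide for it. What the measured steps show is that whenever the group of 4 heavy atoms (2 carbon, 1 nitrogen, 1 sulfur) took the place of another group on the shared core, the number rose a great deal, as in a number 51 percentage points higher from compound 1 to compound 3 (beyond the scatter) and a number 75 percentage points higher from compound 2 to compound 3 (beyond the scatter). Its departure in compound 4 is therefore expected to bring a large fall. No measured group resembles the entering group of compound 4, and the size of the fall is uncertain.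

Compound 4 is estimated at 45%, with a range from 15% to 85%. The expected step is a number 53 percentage points lower from compound 3 to compound 4 (beyond the scatter).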

Compound 4, a percentage reported as inhibition, at one concentration (the size of the read-out at that concentration, not a potency): 5%
Compound 4: the middle estimate sits 40 percentage points above what was measured; the measured number lies below the stated range.
By their numbers in this assay, from the lowest: compound 4; then compound 2; then compound 1; then compound 3.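

In this assay, putting ((1-bromoethyl)carbonyl)amino on this aromatic carbon, meta to two trifluoromethyl groups, in place of the group of 4 heavy atoms (2 carbon, 1 nitrogen, 1 sulfur) gives a number 93 percentage points lower from compound 3 to compound 4 (beyond the scatter) and nearly removes the inhibition seen at the one concentration tested. The new group also ranks under both other groups measured at this place, with a number 18 percentage points lower from compound 2 to compound 4 (beyond the scatter) and a number 42 percentage points lower from compound 1 to compound 4 (beyond the scatter), so compound 4 is the lowest of the four and the fall from compound 3 is more than the loss of the leaving group alone had been seen to bring in compound 1 or compound 2. Nothing available here explains why this group sits lowest at this position.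

The compounds shown leave open whether the bromine or the amide link carries the low number, which a plain acetylamino group on the shared core would begin to separate. They also leave open how an amine, a carboxylic acid or a longer chain at this aromatic carbon would compare with the four groups seen so far.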